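A Longer Chain on Compound 2

This account rests on a few compounds, and the source may have more. Where it says the series, first, only, none or still open, it means among the compounds named here.

In an ADME assay on BaF3 cells (Mus musculus) for antiproliferative activity, read by CCK-8 assay, with a stated time of 72 h (a higher number here means a weaker inhibitor of growth, a lower number a stronger inhibitor of growth), compound 1 `O=C(CCSc1ccc2c(/C=C/c3ccccn3)n[nH]c2c1)Nc1ccc(F)c(C(F)(F)F)c1` gives 610 nM and compound 2 `Cc1ccc(NC(=O)CCSc2ccc3c(/C=C/c4ccccn4)n[nH]c3c2)cc1C(F)(F)F` gives 530 nM, so compound 2 stands level with compound 1 within the scatter. Compound 3 `CN(C)CCN(C)Cc1ccc(NC(=O)CCSc2ccc3c(/C=C/c4ccccn4)n[nH]c3c2)cc1C(F)(F)F` differs from compound 2 by (2-(dimethylamino)ethyl)(methyl)amino in place of hydrogen on a saturated chain carbon bound to an aromatic carbon. Among the measured compounds shown here, the only measured step, a 1.2-fold lower number from compound 1 to compound 2 (0.06 log units; within the scatter), is a swap of methyl in place of fluoro and offers little guidance on such a chain. A modest fall, with wide uncertainty, is therefore expected: a 2.1-fold lower number from compound 2 to compound 3 (0.33 log units; beyond the scatter). The estimate for compound 3 is 250 nM, ranging from 50 nM to 1000 nM.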

Compound 3, concentration for 50% growth inhibition: 1850 nM
Beside the measured number, compound 3's estimate is 7.4-fold (0.87 log units) below it, and the stated range ends below it.
By their numbers in this assay, from the lowest: compounds 2 and 1 (each within the scatter of the next); then compound 3.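

In this assay, the swap of methyl for fluoro left the number within the scatter, but this position does respond to a longer chain: (2-(dimethylamino)ethyl)(methyl)amino in place of hydrogen on a saturated chain carbon bound to an aromatic carbon gives a 3.5-fold higher number from compound 2 to compound 3 (0.54 log units; beyond the scatter). Read from the fluoro neighbour, the change is a 3.0-fold higher number from compound 1 to compound 3 (0.48 log units; beyond the scatter), so both steps point to a weaker inhibitor of growth. Nothing available explains this loss. On these data alone, whether a lone dimethylamino group, a morpholine ring or a carboxylic acid on this carbon would give the same result remains open.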